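Swapping the Benzyl Urea Arm for Diethylamino

The source may hold more compounds than are shown below. What is called first, only, known or untested is meant among the compounds shown, and "the series" means these compounds.

Compound 1, `COc1cc(NC(C)CCCNC(=O)NC(c2ccccc2)c2ccccc2)c2ncccc2c1`, gives only a limit of > 500000 nM in a functional assay on L1210 cells (Mus musculus), read by MTT assay, with a stated time of 72 h; a lower number here means a stronger inhibitor, a higher number a weaker inhibitor.
Compound 2, `COc1cc(NC(C)CCCNC(=O)NCc2ccccc2)c2ncccc2c1`, gives 22000 nM in this assay.

Among the measured compounds shown here, compound 2 holds the only real number here; the other value is a limit. For the measured compounds named here, the one measured step, an at least 22-fold lower number from compound 1 to compound 2 (1.35 log units; beyond the scatter), removed a phenyl from the urea side chain. Compound 3, `CCN(CC)C(=O)NCCCC(C)Nc1cc(OC)cc2cccnc12`, differs from compound 2 by diethylamino in place of benzylamino on a carbonyl carbon, again trimming that arm but also losing its ring and its donor, so the earlier step bears only loosely. A step within the scatter is expected, a 1.1-fold higher number from compound 2 to compound 3 (0.06 log units; within the scatter). Compound 3 is estimated at 25000 nM, between 6000 nM and 120000 nM.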

Compound 3, half-maximal inhibitory concentration: 207000 nM
Compound 3: the middle estimate sits 8.3-fold (0.92 log units) below what was measured, and the stated range ends below it.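

In this assay, diethylamino in place of benzylamino on the carbonyl carbon brings a 9.4-fold higher number from compound 2 to compound 3 (0.97 log units; beyond the scatter). Removing a phenyl from this arm gave an at least 22-fold lower number from compound 1 to compound 2 (1.35 log units; beyond the scatter), so making the arm smaller does not by itself lower the number. The change removes the ring and a hydrogen-bond donor together, and nothing shown gives a cause for the step.

A cyclohexylamino arm, which has a donor but no aromatic ring, could help separate the two. So could a benzyl(methyl)amino arm, which has the ring but no donor.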